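The compounds below may be only part of what the source reports. "The series", "measured", "known", "first", "only" and "open" are said of these compounds alone.

Measured compounds:
- compound 1, `Cc1cccc(C#CC2=C/C(=N/Oc3cccc(F)n3)CCC2)n1`: 46.8 nM
- compound 2, `Fc1cccnc1O/N=C1/C=C(C#Cc2ccccn2)CCC1`: 4.01 nM
- compound 3, `Fc1cccc(O/N=C2\C=C(C#Cc3ccccn3)CCC2)n1`: 44 nM

These three compounds share a core built around an alkyne that links a pyridine to a cyclohexenone-derived oxime ether, and all three were tested in an assay on brain (strain Sprague-Dawley) for displacement of a labelled ligand from metabotropic glutamate receptor 5 (Rattus norvegicus), with a stated time of 45 min; on this read-out higher numbers stand for weaker inhibition and lower numbers for stronger inhibition. Compound 2 gives 4.01 nM, the lowest number of the three. Compound 3 gives 44 nM and compound 1 gives 46.8 nM; both of these gaps to compound 2 lie beyond the usual scatter, so compound 2 is the most potent of the three here.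

The next compound, compound 4, `CO/N=C1/C=C(C#Cc2ccccn2)CCC1`, has not yet been tested. It differs from compound 2 in one place: methyl in place of 3-fluoropyridin-2-yl on an oxygen. The aryl group on the oxime oxygen is thus replaced by the smallest possible substituent. Among the measured compounds shown here, no pair among the measured compounds changes this oxygen substituent, so the three numbers above give no direct guide to the size of this step. A loss of such a large group in this assay is expected to weaken binding, probably by a step beyond the scatter, though how far is uncertain. Compound 4 is therefore estimated at 60 nM, with a range from 10 nM to 400 nM, which would mean an expected step of a 15-fold higher number from compound 2 to compound 4 (1.18 log units; beyond the scatter).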

Compound 4, inhibition constant: 2.2 nM
Estimate against measurement, compound 4: 27-fold (1.44 log units) above; the measured number lies below the stated range.
By their numbers in this assay, from the lowest: compounds 4 and 2 (each within the scatter of the next); then compounds 3 and 1 (each within the scatter of the next).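

In this assay, among the compounds shown here, putting methyl in place of 3-fluoropyridin-2-yl on the oxygen gives a 1.8-fold lower number from compound 2 to compound 4 (0.26 log units; within the scatter) and so offers the first direct look at this position, where the two compounds cannot be told apart on this read-out. For this pair, the aromatic ring on the oxygen can go, and a group of 7 heavy atoms can shrink to a single carbon, with no change in binding that rises above the usual scatter, so the ring is not required for the low number of compound 2. No separate measurement bears on the reason for this result.

The compounds shown leave open what happens at sizes other than these two, such as an ethyl group or a longer chain on the same oxygen, and whether the number stays in the same range as the group grows. Also open, going by these compounds, are a plain hydrogen on that oxygen, which would give the free oxime, and a chain ending in an amine or a carboxylic acid.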